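The source may hold more compounds than are shown below. What is called first, only, known or untested is meant among the compounds shown, and "the series" means these compounds.

Measured compounds:
In an ADME assay on Vero cells (Chlorocebus sabaeus) for cytotoxicity, read by MTT assay, with a stated time of 72 h (on this read-out higher numbers stand for weaker inhibition and lower numbers for stronger inhibition), compound 1 `CN(C)C(=O)C[C@H](CSc1ccccc1)Nc1c(C(=O)N/N=C/c2ccc(OC(F)(F)F)cc2)cnc2c(C(F)(F)F)cccc12` gives > 62.5 ug/mL, a limit of the assay.
In this assay compound 2 `CN(C)C(=O)C[C@H](CSc1ccccc1)Nc1c(C(=O)N/N=C/c2cccnc2)cnc2c(C(F)(F)F)cccc12` gives > 62.5 ug/mL, also a limit.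
In this assay compound 3 `CN(C)C(=O)C[C@H](CSc1ccccc1)Nc1c(C(=O)N/N=C/c2ccc(OC(F)(F)F)cc2)cnc2ccc(F)cc12` gives > 62.5 ug/mL, again a limit.

Compound 2 arises from compound 1 by pyridin-3-yl in place of 4-(trifluoromethoxy)phenyl on a carbon with a double bond to nitrogen, and the step that the two limits leave unreadable from compound 1 to compound 2 cannot be read because both values are limits. How the core of compound 1 differs from the core of compound 3 is not broken down here. Compound 4 `CN(C)C(=O)C[C@H](CSc1ccccc1)Nc1c(C(=O)N/N=C/c2cccnc2)cnc2ccc(F)cc12` is made from compound 3 by pyridin-3-yl in place of 4-(trifluoromethoxy)phenyl on a carbon with a double bond to nitrogen, the same change. Since (the limit of > 62.5 ug/mL in this assay, at which 3 of the 3 values shown sit), compound 3 and compound 4 are expected to be separated by a step that the limit leaves unreadable from compound 3 to compound 4, resting on the unreadable step from compound 1 to compound 2. Compound 4 is therefore expected to give about 90 ug/mL in this assay, with a range from 40 ug/mL to 250 ug/mL, most likely reported only as a limit.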

Compound 4, half-maximal inhibitory concentration: > 62.5 ug/mL
Compound 4 gave a limit, no number (the forecaster's own chance of this, stated with the estimate: 85%); the middle value does not contradict the limit.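

In this assay the step from compound 3 to compound 4 cannot be read, since both values are limits: the limit of > 62.5 ug/mL in this assay, at which 4 of the 4 values shown sit.

The compounds shown leave open whether the pyridin-3-yl and 4-(trifluoromethoxy)phenyl compounds, or the two cores, differ at all in this assay.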